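A Ring Swap on the Pyridine Tail of Compound 2

The source may report more compounds than this note shows. Statements on the series, on what has been measured and on what is new or still open speak of the compounds shown alone.

Of the compounds shown here, two have been measured in an assay on cells for inhibition of cytochrome P450 11B2, mitochondrial (Homo sapiens), read by HTRF; a higher number here means a weaker inhibitor, a lower number a stronger inhibitor. Compound 1 `CCC(=O)NCc1cncc(N2C(=O)c3ccc(Cl)cc3C2(C)C)c1` gives 282 nM, and compound 2 `CC(=O)N1CCN(c2cncc(N3C(=O)c4ccc(Cl)cc4C3(C)C)c2)CC1` gives 9 nM. Compound 2 thus holds the lowest of the two numbers; its nearest neighbour is compound 1, and the step of a 31-fold lower number from compound 1 to compound 2 (1.50 log units; beyond the scatter) separates them, a large one beyond the scatter. Compound 3 `CC(=O)N1CC[C@@H](Oc2cncc(N3C(=O)c4ccc(Cl)cc4C3(C)C)c2)C1` is the next candidate. It differs from compound 2 by a group of 9 heavy atoms (6 carbon, 1 nitrogen, 2 oxygen; one five-membered non-aromatic ring with 1 hetero atom) in place of a group of 9 heavy atoms (6 carbon, 2 nitrogen, 1 oxygen; one six-membered non-aromatic ring with 2 hetero atoms), on an aromatic carbon; the entering group has no common name. Among the measured compounds shown here, no measured step matches this change directly; the only step at hand, the one from compound 1 to compound 2, shows that an acetylated ring tail on this aromatic carbon can carry a large gain. With a ring of different size and a different attachment, compound 3 is expected to stay within a modest distance of compound 2, with a 2.2-fold higher number from compound 2 to compound 3 (0.35 log units; beyond the scatter) as the expected step. Compound 3 is therefore estimated at 20 nM, ranging from 5 nM to 80 nM.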

Compound 3, half-maximal inhibitory concentration: 11 nM
Beside the measured number, compound 3's estimate is 1.8-fold (0.26 log units) above it; low and high end bracket the measured number.
By their numbers in this assay, from the lowest: compounds 2 and 3 (each within the scatter of the next); then compound 1.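

In this assay, replacing 4-acetylpiperazin-1-yl with the five-membered ring with 1 hetero atom gives a 1.2-fold higher number from compound 2 to compound 3 (0.09 log units; within the scatter), so this position, two atoms from the ring nitrogen, accepts both acetylated ring tails with no difference beyond the scatter. The large distance from the open chain of compound 1 also holds for the new ring, with a 26-fold lower number from compound 1 to compound 3 (1.41 log units; beyond the scatter), which shows that it is not confined to the 4-acetylpiperazin-1-yl group of compound 2. Nothing available bears on why these two different ring tails give values within the scatter of each other.

The compounds shown leave open how the number would move with a free amine or a methanesulfonyl group in place of the acetyl on the ring nitrogen. They also leave open what the opposite configuration at the stereocentre of compound 3 would give.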